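Adding a Hydroxy Group to Compound 1

A few compounds are considered here, and "the series" means these few. Any claim that something is new, unique, unknown or untested is made for them only; others in the source may bear on it.

Compound 1 `CC(C)=CCc1c(O)cc(/C=C/c2ccccc2)cc1O` carries a 3-methylbut-2-en-1-yl group on an aromatic carbon of its core. Among the measured compounds shown here, in a physicochemical assay for lipophilicity, read by HPLC, measured as octanol-water partition (on this read-out lower numbers stand for lower lipophilicity and higher numbers for higher lipophilicity), compound 1 gives 3.46, the second highest of the three numbers measured so far. Its nearest neighbour is compound 2 `CC(C)/C=C/c1c(O)cc(/C=C/c2ccccc2)cc1O`, which in this assay gives 3.71. For the measured compounds named here, the single recorded step, a number 0.25 log units higher from compound 1 to compound 2 (within the scatter), exchanges one chain for another and is a small one. The furthest is compound 3 `COc1cccc(/C=C/c2ccc(O)cc2)c1`, which in this assay gives 3.14, lower than compound 1 by a margin beyond the scatter.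

Compound 4 `CC(C)=CCc1c(O)cc(/C=C/c2ccc(O)cc2)cc1O` has not yet been measured. It differs from compound 1 in one place: hydroxy in place of hydrogen on an aromatic carbon. Going by the values given here, no measured step bears directly on this change: the step from compound 1 to compound 2 concerns 3-methylbut-1-en-1-yl in place of 3-methylbut-2-en-1-yl, not a hydroxy, and compound 3 differs from the others in more than one place, so its value alone cannot isolate the effect of a hydroxy group.

The expectation therefore rests on the structural change itself. A hydroxy entering in place of hydrogen is expected to move this assay downward by a step beyond the scatter, a number 0.61 log units lower from compound 1 to compound 4 (beyond the scatter). Compound 4 is accordingly estimated at 2.85, with a range from 2.4 to 3.3.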

Compound 4, partition coefficient: 2.56
Compound 4: the middle estimate sits 0.29 log units above what was measured; the measured number falls inside the stated range.
By their numbers in this assay, from the lowest: compound 4; then compound 3; then compounds 1 and 2 (each within the scatter of the next).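

Hydroxy in place of hydrogen, on an aromatic carbon para to a large group, turns the phenyl of compound 1 into 4-hydroxyphenyl and leaves the 3-methylbut-2-en-1-yl group as it stands. In this assay, among the compounds shown here, this single change gives a number 0.90 log units lower from compound 1 to compound 4 (beyond the scatter) and so provides the first reading of a change at this position, since the earlier step concerned only the chain. That earlier step, a number 0.25 log units higher from compound 1 to compound 2 (within the scatter) and nothing more, is the smaller of the two, and only the new step lies beyond the scatter, so the phenyl position shows a clear response where the exchange of chains did not. No evidence is available to explain the size of this step.

The step rests on one pair alone, and the compounds shown leave open whether an amine or a carboxylic acid in the same place on the phenyl would move the read-out as far as hydroxy does. They also leave open whether hydroxy in this place would give a step of the same size on compound 2 with its 3-methylbut-1-en-1-yl chain.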